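The source may report more compounds than this note shows. Statements on the series, on what has been measured and on what is new or still open speak of the compounds shown alone.

Measured in a functional assay on MCF7 cells (Homo sapiens) for antiproliferative activity, read by MTT assay, with a stated time of 48 h; on this read-out lower numbers stand for stronger inhibition and higher numbers for weaker inhibition:
- compound 1 `CC[C@@H](C)[C@H](NC(=O)c1ccc(Oc2nc3ccccc3nc2C)cc1)C(=O)OC`: 36100 nM
- compound 2 `COC(=O)[C@H](C)NC(=O)c1ccc(Oc2nc3ccc(Cl)cc3nc2C)cc1`: 33800 nM
- compound 3 `COC(=O)[C@H](CC(C)C)NC(=O)c1ccc(Oc2nc3ccc(Cl)cc3nc2C)cc1`: 22800 nM

The values of all three compounds lie within the usual scatter of one another, so compound 1 cannot be separated from compound 2 or compound 3. Compound 4 `CC[C@@H](C)[C@H](NC(=O)c1ccc(Oc2nc3ccccc3nc2C)cc1)C(=O)O` differs from compound 1 by one change: hydrogen in place of methyl on an oxygen next to a carbonyl group. Its methoxycarbonyl becomes carboxy, with hydrogen in place of methyl on an oxygen next to a carbonyl group. Going by the values given here, the only measured step, a 1.5-fold lower number from compound 2 to compound 3 (0.17 log units; within the scatter), lies at a different place, so no measurement shows what this change does. With no evidence for a shift, no step beyond the scatter is expected, though the uncertainty is wide. The expected step is a 1.0-fold lower number from compound 1 to compound 4 (0.00 log units; within the scatter). For compound 4 the estimate in this assay is 36000 nM, with an expected range from 12000 nM to 100000 nM.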

Compound 4, half-maximal inhibitory concentration: 35700 nM
Compound 4: middle estimate off by 1.0-fold (0.00 log units), on the high side, and the stated range covers the measured number.
By their numbers in this assay, from the lowest: compounds 3, 2, 4 and 1 (each within the scatter of the next).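

In this assay, going by these compounds alone, the change from methoxycarbonyl to carboxy gives a 1.0-fold lower number from compound 1 to compound 4 (0.00 log units; within the scatter) in a series where every value so far lies within the scatter. At this position, then, hydrogen in place of methyl on an oxygen next to a carbonyl group leaves the number indistinguishable, and the ester methyl is not needed to keep this level of activity. The compounds shown leave open whether a primary amide or a longer ester, such as an ethyl ester, would read the same at this place. Nothing measured here explains the result.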